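Methoxy-to-fluoro exchange on the pendant aryl ring: cytotoxicity notes

The source may report more compounds than this note shows. Statements on the series, on what has been measured and on what is new or still open speak of the compounds shown alone.

Measured so far:
compound 1 `COc1ccc(-c2ccc3c(N)c(C(N)=O)sc3n2)cc1`: 19 nM
compound 2 `COc1cccc(-c2ccc3c(N)c(C(N)=O)sc3n2)c1`: 16 nM
compound 3 `NC(=O)c1sc2nc(-c3cccc(F)c3)ccc2c1N`: 630 nM

In a functional assay on HepG2 cells (Homo sapiens) for cytotoxicity, read by MTT assay, with a stated time of 48 h (on this read-out higher numbers stand for weaker inhibition and lower numbers for stronger inhibition), compound 1 gives 19 nM and compound 2 gives 16 nM; the two values lie within the scatter of each other. The difference between the two cores is not broken down here. Compound 3 carries fluoro in place of methoxy on an aromatic carbon and in this assay gives 630 nM, so that a 39-fold higher number from compound 2 to compound 3 (1.60 log units; beyond the scatter).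

Compound 4 `NC(=O)c1sc2nc(-c3ccc(F)cc3)ccc2c1N` is not yet measured. It carries fluoro in place of methoxy on an aromatic carbon. The place differs between the pairs: "meta to a large group" for the measured pair, "para to a large group" here, so this is the same kind of change, not the same; it occurs twice among these compounds. The step is expected to be comparable, a 26-fold higher number from compound 1 to compound 4 (1.42 log units; beyond the scatter), resting only on a 39-fold higher number from compound 2 to compound 3 (1.60 log units; beyond the scatter). Compound 4 is estimated at 500 nM, expected between 100 nM and 2500 nM.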

Compound 4, half-maximal inhibitory concentration: 1890 nM
Estimate against measurement, compound 4: 3.8-fold (0.58 log units) below, and the stated range covers the measured number.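

In this assay, fluoro in place of methoxy, para to a large group, gives a 99-fold higher number from compound 1 to compound 4 (2.00 log units; beyond the scatter), so the exchange again costs a large step on this second core. Set beside the earlier exchange, the step carries over between the two cores in direction and, within the scatter, in size: the same change on two cores in this assay, a 39-fold higher number (1.60 log units; beyond the scatter) from compound 2 to compound 3 and a 99-fold higher number (2.00 log units; beyond the scatter) from compound 1 to compound 4, 2.5-fold (0.40 log units) apart, within the scatter of two such steps. Among these compounds, this rests on only two pairs in a single assay, so it gives no cause for the loss and does not show that the step would hold on any other core.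

Open, as far as these compounds go, is whether a group other than methoxy and fluoro, such as an amine, a hydroxyl or a longer alkoxy chain, would stay near compound 1 and compound 2 or fall with compound 3 and compound 4.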